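The source may report more compounds than this note shows. Statements on the series, on what has been measured and on what is new or still open speak of the compounds shown alone.

Compound 1 `Cc1cc(C)cc(-n2nncc2CN2C(=O)C3(C(C#N)=C(N)Oc4c3c3nc5ccccc5nc3c3ccccc43)c3ccccc32)c1` and compound 2 `N#CC1=C(N)Oc2c(N)cc3nc4ccccc4nc3c2C12C(=O)N(Cc1cnnn1-c1ccc(Cl)cc1)c1ccccc12` share one core and differ only in the group on the triazole nitrogen. In an ADME assay on HUVEC cells (Homo sapiens) for antiproliferative activity, read by MTT assay, with a stated time of 48 h (a higher number here means a weaker inhibitor, a lower number a stronger inhibitor), compound 1 gives > 50000 nM, which is a limit of the assay and not a number. In this assay compound 2 gives > 50000 nM, again a limit rather than a number. Both measured values thus sit at the limit of > 50000 nM in this assay, at which 2 of the 2 values shown sit, and compound 2 stands there with compound 1, without a gradient between them. Compound 3 `CCOc1ccccc1-n1nncc1CN1C(=O)C2(C(C#N)=C(N)Oc3c(N)cc4nc5ccccc5nc4c32)c2ccccc21` has not been measured in this assay. It differs from compound 2 by 2-ethoxyphenyl in place of 4-chlorophenyl on an aromatic nitrogen. For the measured compounds named here, with no measured step between compounds and both values at the limit, no shift beyond the scatter is expected in either direction. The expected step from compound 2 to compound 3 in this assay is a step that the limit leaves unreadable from compound 2 to compound 3. Compound 3 is estimated at 60000 nM in this assay, within 20000 nM to 200000 nM, most likely reported again as a limit.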

Compound 3, half-maximal inhibitory concentration: > 50000 nM
Compound 3: only a limit was reported (the forecaster's own chance of this, stated with the estimate: 85%); the middle value lies beyond the limit too.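

In this assay compound 3 gives > 50000 nM, a limit and not a number, so no step between compound 2 and compound 3 can be read: the limit of > 50000 nM in this assay, at which 3 of the 3 values shown sit.

The compounds shown leave open whether any group on the aromatic nitrogen gives a measurable value in this assay.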